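This account rests on a few compounds, and the source may have more. Where it says the series, first, only, none or still open, it means among the compounds named here.

Compounds 1, 2 and 3 share one core, shown in compound 1 `CCOC(=O)c1c(-c2cccc(Oc3ccccc3)c2)[nH]c2cc(OC)ccc2c1=O`. In an ADME assay on BJ cells (Homo sapiens) for cytotoxicity, read by luminescence, with a stated time of 72 h (on this read-out higher numbers stand for an effect only at larger amounts of compound and lower numbers for an effect already at smaller amounts), compound 1 gives only a limit, > 21500 nM. Compound 2 `CCOC(=O)c1c(-c2cccc(Oc3ccccc3)c2)[nH]c2cc(OC)c(OC)cc2c1=O` gives a limit as well in this assay, > 21500 nM. Compound 3 `CCOC(=O)c1c(-c2cccc(Oc3ccccc3)c2)[nH]c2cc(OC)c(F)cc2c1=O` again gives a limit in this assay, > 21500 nM. The steps a step that the two limits leave unreadable from compound 1 to compound 2, a step that the two limits leave unreadable from compound 1 to compound 3 and a step that the two limits leave unreadable from compound 2 to compound 3 thus carry no readable size, and compound 3 sits at the limit of > 21500 nM in this assay, at which 3 of the 3 values shown sit. Compound 4 `CCOC(=O)c1c(-c2cccc(-c3ccccc3Cl)c2)[nH]c2cc(OC)c(F)cc2c1=O` differs from compound 3 by 2-chlorophenyl in place of phenoxy on an aromatic carbon. Going by the values given here, none of the measured steps touches this position or this kind of exchange, so they set neither size nor direction. The expected step in this assay is a step that the limit leaves unreadable from compound 3 to compound 4. Compound 4 is estimated at 25000 nM, with a range of 10000 nM to 60000 nM, and a limit-only result is expected to remain likely.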

Compound 4, half-maximal effective concentration: > 21500 nM
Compound 4 ended at the assay's limit; the forecaster's own chance of this, stated with the estimate: 70%; the middle value lies beyond the limit too.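

Going by these compounds alone, compound 3 and compound 4 both give only limits, so no step between them can be read: the limit of > 21500 nM in this assay, at which 4 of the 4 values shown sit.

Still open is whether 2-chlorophenyl in place of phenoxy changes the read-out in this assay, and at what concentration any compound shown has an effect.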